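The source may report more compounds than this note shows. Statements on the series, on what has been measured and on what is new or still open speak of the compounds shown alone.

Measured so far:
compound 1 `COC(=O)c1c(Nc2ccc(C)cc2)sc(C(=O)c2ccc(OC)cc2)c1C` — "not active" (no number reported)
compound 2 `COC(=O)c1c(Nc2ccc(F)cc2)sc(C(=O)c2ccc(OC)cc2)c1C` — 25.6%

In a functional assay, with a stated time of 150 min, tested at 35 ug/mL (on this read-out lower numbers stand for a weaker effect and higher numbers for a stronger effect at the one concentration tested), compound 1 is recorded as "not active" (no number reported), with no single number, so it stands at the weak end of what has been measured. In this assay compound 2 gives 25.6%. Compound 3 `COc1ccc(C(=O)c2sc(Nc3ccc(C)cc3)c(C(=O)O)c2C)cc1` is the next entry and differs from compound 1 in one place: hydrogen in place of methyl on an oxygen next to a carbonyl group. For the measured compounds named here, no measured pair in this assay shows this change, so its size is unknown; on the little there is, no step beyond the scatter is expected in either direction, and compound 3 is expected to stay low. Estimate for compound 3 in this assay: 10%, within 0% to 30%.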

Compound 3, a percentage reported as activity, at one concentration (the size of the read-out at that concentration, not a potency): "not active" (no number reported)
Compound 3: no number reported, and the estimate cannot be compared.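

In this assay compound 1 gives "not active" (no number reported) and compound 3 gives "not active" (no number reported), so no step can be read between them. The compounds shown leave open what size, if any, the change from methoxycarbonyl to carboxy has on this read-out. No measured evidence bears on this result.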